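Methoxy added next to the hydroxy of a dioxygenase inhibitor

This account rests on a few compounds, and the source may have more. Where it says the series, first, only, none or still open, it means among the compounds named here.

Measured compounds:
compound 1 `O=C(Cc1cccnc1)c1cc2cc(-c3ccccc3)ccc2[nH]1` 96000 nM
compound 2 `O=C(Cc1cccnc1)c1cc2c(O)cccc2[nH]1` 83000 nM
compound 3 `O=C(Cc1cnccn1)c1cc2ccccc2[nH]1` 26200 nM

In an assay on isolated protein for inhibition of Indoleamine 2,3-dioxygenase 1 (Homo sapiens), read by spectrophotometry (on this read-out lower numbers stand for stronger inhibition and higher numbers for weaker inhibition), compound 2 gives 83000 nM, the second highest of the three numbers. Compound 1 gives 96000 nM, which lies within the scatter of compound 2. Compound 3 gives 26200 nM, a lower number than compound 2 and beyond the scatter.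

Compound 4 `COc1ccc2[nH]c(C(=O)Cc3cccnc3)cc2c1O` has not yet been measured in this assay. It differs from compound 2 by methoxy in place of hydrogen on an aromatic carbon. Among the compounds with values here, no measured pair shows this change, so no step in this assay is known for it. Compound 4 is estimated at 70000 nM, with a range from 25000 nM to 200000 nM. The expected step from compound 2 to compound 4 is a 1.2-fold lower number from compound 2 to compound 4 (0.07 log units; within the scatter), a change not expected to exceed the scatter.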

Compound 4, half-maximal inhibitory concentration: 63000 nM
Estimate against measurement, compound 4: 1.1-fold (0.05 log units) above; low and high end bracket the measured number.
By their numbers in this assay, from the lowest: compound 3; then compounds 4, 2 and 1 (each within the scatter of the next).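

In this assay, methoxy in place of hydrogen on an aromatic carbon, ortho to a hydroxy group, gives a 1.3-fold lower number from compound 2 to compound 4 (0.12 log units; within the scatter), a step within the scatter. Within the data shown here, this is the first reading of any change at this position of the shared core, and here the added methoxy leaves the number where it was, within the scatter. Nothing available bears on the reason for this result. Going by these compounds, what an amine or a carboxylic acid in place of the methoxy would do stays open, and so does whether the methoxy step would hold without the hydroxy group.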